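The source may hold more compounds than are shown below. What is called first, only, known or untested is meant among the compounds shown, and "the series" means these compounds.

Working notes on the series.

Compound 1 `O=C(O)Cc1sc(C(c2ccccc2)c2ccccc2)nc1-c1ccc(C(F)(F)F)cc1` carries diphenylmethyl and a trifluoromethyl-substituted phenyl on the shared core. In an in vitro functional assay on HEK285-7 cells for antagonist activity at prostaglandin D2 receptor 2 (Homo sapiens), read by BRET and beta-arrestin recruitment (a higher number here means a weaker inhibitor, a lower number a stronger inhibitor), compound 1 gives > 100000 nM, which is a limit of the assay and not a number. Of the values shown for compound 1, one sits at the limit of > 100000 nM in this assay, at which 1 of the 2 values shown sits.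

Compound 2 `O=C(O)Cc1sc(C(c2ccc(F)cc2)c2ccc(F)cc2)nc1-c1ccncc1` replaces both of those groups, bearing a bis(4-fluorophenyl)methyl group and a pyridin-4-yl ring. In this assay compound 2 gives 40 nM. Among the compounds with values here, compound 2 therefore stands as the only numerical value in the set; the one other value is a limit, so no measured step between compounds can be counted.

Compound 3 `O=C(O)Cc1sc(C(c2ccc(F)cc2)c2ccc(F)cc2)nc1-c1ccnc(N2CCCC2)c1` is not yet measured. It differs from compound 2 by pyrrolidin-1-yl in place of hydrogen on an aromatic carbon; read one bond further out, pyridin-4-yl becomes 2-(pyrrolidin-1-yl)pyridin-4-yl. Within the data shown here, no measured pair illustrates this change, so the expected step from compound 2 to compound 3 is small, a 1.3-fold higher number from compound 2 to compound 3 (0.10 log units; within the scatter), with no direction beyond the scatter firmly expected. Compound 3 is estimated at 50 nM, with a likely range from 10 nM to 250 nM in this assay.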

Compound 3, half-maximal inhibitory concentration: > 100000 nM
Compound 3: only a limit was reported (the forecaster's own chance of this, stated with the estimate: 2%); middle value at least 2000-fold (3.30 log units) from the limit.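

Within the data shown here, the first measured step is an at least 2500-fold higher number from compound 2 to compound 3 (3.39 log units; beyond the scatter), for pyrrolidin-1-yl in place of hydrogen on an aromatic carbon next to the ring nitrogen. In this assay compound 3 gives > 100000 nM, which is a limit of the assay and not a number. Compound 1 and compound 2 differ in two places and could not show the effect of a single change, whereas this pair shows that one substitution at this position of the pyridin-4-yl ring is enough to take a measurable inhibitor to the limit, the reading already seen for compound 1: the limit of > 100000 nM in this assay, at which 2 of the 3 values shown sit.

The compounds shown leave open whether a smaller group on this carbon, such as methyl, methoxy or an open-chain amine such as dimethylamino, would keep a number close to that of compound 2, and so whether the loss follows from the pyrrolidine ring or from any replacement of hydrogen here. Going by these compounds, the step also ends at a limit, so its full size remains unknown, and a single substituent at one position says nothing about the other carbons of the pyridine ring.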